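A few compounds are considered here, and "the series" means these few. Any claim that something is new, unique, unknown or untested is made for them only; others in the source may bear on it.

In an assay on RBL-1 cells with Polyunsaturated fatty acid 5-lipoxygenase (Rattus norvegicus) as the target (on this read-out higher numbers stand for weaker inhibition and lower numbers for stronger inhibition), compound 1 `Cc1ccc2ccccc2c1O` gives 130 nM and compound 2 `Oc1c(Cc2ccccn2)ccc2ccccc12` gives 390 nM. Among the compounds with values here, the single measured step, a 3.0-fold higher number from compound 1 to compound 2 (0.48 log units; beyond the scatter), leaves compound 2 at the higher of the two numbers in this assay, with compound 1 as its only comparator. Compound 3 `Oc1c(Cc2cccnc2)ccc2ccccc12` differs from compound 2 by pyridin-3-yl in place of pyridin-2-yl on a saturated chain carbon bound to an aromatic carbon. Within the data shown here, no measured step exchanges one pyridyl isomer for another; the only step recorded, from hydrogen to pyridin-2-yl, bears on the presence of the ring rather than on which pyridyl isomer is attached, so it gives no direction for this change. The expectation is therefore a step of a 1.0-fold higher number from compound 2 to compound 3 (0.01 log units; within the scatter) in this assay, not beyond the scatter in either direction. Compound 3 is expected to give 400 nM in this assay, with a range from 150 nM to 1100 nM.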

Compound 3, half-maximal inhibitory concentration: 230 nM
Estimate against measurement, compound 3: 1.7-fold (0.24 log units) above, within the range that was stated.
By their numbers in this assay, from the lowest: compounds 1, 3 and 2 (each within the scatter of the next, the first and the last beyond it).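

Working from this assay, pyridin-3-yl in place of pyridin-2-yl on a saturated chain carbon bound to an aromatic carbon gives (a 1.7-fold lower number from compound 2 to compound 3 (0.23 log units; within the scatter)), so this first exchange of one pyridyl isomer for another does not separate the two beyond the scatter. Pyridin-3-yl in place of hydrogen gives (a 1.8-fold higher number from compound 1 to compound 3 (0.25 log units; within the scatter)), whereas pyridin-2-yl in place of hydrogen gave (a 3.0-fold higher number from compound 1 to compound 2 (0.48 log units; beyond the scatter)), so a step beyond the scatter from the hydrogen compound is seen with pyridin-2-yl only, and that contrast rests on two isomers that lie within the scatter of each other. Nothing available accounts for these numbers.

Open, from the compounds shown here alone, is how pyridin-4-yl or a plain phenyl ring would read at this place. Also open is whether a longer chain carrying the pyridine ring, or an amine or carboxylic acid in its stead, would leave the number within the scatter of these compounds.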